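A few compounds are considered here, and "the series" means these few. Any claim that something is new, unique, unknown or untested is made for them only; others in the source may bear on it.

In a physicochemical assay for lipophilicity, read by spectrophotometry, measured as octanol-water partition, at pH 7.4 (a higher number here means a more lipophilic compound, a lower number a more polar compound), compound 3 (`CCOc1cc(CN2CCC(NC(=O)c3cncc(C)c3)CC2)cc(OCC)c1-c1ccc(F)cc1`) stands highest of the three measured compounds at 4.01, with compound 2 (`CCOc1cc(CN2CCC(NC(=O)c3ccc(Cl)nc3)CC2)cc(OCC)c1-c1ccc(F)cc1`) at 3.55 and compound 1 (`CCOc1cc(CN2CCC(NC(=O)c3ccc(NC)nc3)CC2)cc(OCC)c1F`) at 2.66. Next is compound 4 (`CCOc1cc(CN2CCC(NC(=O)c3ccc(NC)nc3)CC2)cc(OCC)c1-c1ccc(F)cc1`), with the change 6-(methylamino)pyridin-3-yl in place of 5-methylpyridin-3-yl on a carbonyl carbon. Among the compounds with values here, the only measured step at this place, a number 0.46 log units higher from compound 2 to compound 3 (beyond the scatter), was modest but beyond the scatter. Within the data shown here, this exact swap has no measured precedent. Compound 1 carries the entering group on another core and sits lowest at 2.66, which points downward. A modest fall in this assay is therefore expected, and the expected change is a number 0.41 log units lower from compound 3 to compound 4 (beyond the scatter). For compound 4 the estimated value is 3.6, within a range of 3.2 to 4.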

Compound 4, distribution coefficient: 3.83
Compound 4: middle estimate off by 0.23 log units, on the low side; low and high end bracket the measured number.
By their numbers in this assay, from the lowest: compound 1; then compounds 2, 4 and 3 (each within the scatter of the next, the first and the last beyond it).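

In this assay the swap to 6-(methylamino)pyridin-3-yl on the carbonyl carbon gives a number 0.18 log units lower from compound 3 to compound 4 (within the scatter) and methylamino in place of chloro on an aromatic carbon gives a number 0.28 log units higher from compound 2 to compound 4 (within the scatter) so neither change at this position clears the scatter, unlike a number 0.46 log units higher from compound 2 to compound 3 (beyond the scatter) between the two earlier compounds. The large step lies at the other place: 4-fluorophenyl in place of fluoro on an aromatic carbon gives a number 1.17 log units higher from compound 1 to compound 4 (beyond the scatter) with the 6-(methylamino)pyridin-3-yl group held constant. No measurement bearing on the origin of these steps is at hand.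

Open, on these data alone, is whether a carboxylic acid or a morpholine in place of methylamino would move the number beyond the scatter.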